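The source may hold more compounds than are shown below. What is called first, only, known or untested is meant among the compounds shown, and "the series" means these compounds.

Compound 1 `CCCCCOC(=O)CCC(=O)N1CCN(CCCOc2cc3c(Nc4ccc(F)c(Cl)c4)ncnc3cc2OC)CC1`, in a functional assay on A549 cells (Homo sapiens) for cytotoxicity, read by MTT assay, with a stated time of 24 h, tested at 20 uM; on this read-out higher numbers stand for a weaker effect at the one concentration tested and lower numbers for a stronger effect: 81.2%
Compound 2 `CCCCCCCCOC(=O)CCC(=O)N1CCN(CCCOc2cc3c(Nc4ccc(F)c(Cl)c4)ncnc3cc2OC)CC1`, in this assay: 80%

Within the data shown here, compound 2 sits within the scatter of compound 1, the only other number in this assay, so the two cannot be told apart. Among the measured compounds shown here, the one measured step, a number 1.2 percentage points lower from compound 1 to compound 2 (within the scatter), lengthened the same chain and stayed within the scatter. Compound 3 `CCCCCCCCCCOC(=O)CCC(=O)N1CCN(CCCOc2cc3c(Nc4ccc(F)c(Cl)c4)ncnc3cc2OC)CC1` differs from compound 2 by ethyl in place of hydrogen on a saturated chain carbon, eight bonds along the chain from an oxygen next to a carbonyl group, a further lengthening of that chain. For the measured compounds named here, as the one comparable step showed nothing beyond the scatter, compound 3 is expected to give 79% in this assay, between 67% and 91%, meaning an expected step of a number 1 percentage points lower from compound 2 to compound 3 (within the scatter).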

Compound 3, a percentage reported as activity, at one concentration (the size of the read-out at that concentration, not a potency): 88.2%
Estimate against measurement, compound 3: 9.2 percentage points below, and the stated range covers the measured number.
By their numbers in this assay, from the lowest: compounds 2, 1 and 3 (each within the scatter of the next).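

In this assay, ethyl in place of hydrogen eight bonds along the chain (a number 8.2 percentage points higher from compound 2 to compound 3 (within the scatter)) and pentyl in place of hydrogen five bonds along it (a number 7 percentage points higher from compound 1 to compound 3 (within the scatter)) both stay within the scatter. Compound 1, compound 2 and compound 3 therefore cannot be told apart, and this now holds over a longer stretch of the chain than the first step covered. Nothing available here bears on a cause for this result. The compounds shown leave open whether a carboxylic acid or an amine at the end of this chain would give a number beyond the scatter.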